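A few compounds are considered here, and "the series" means these few. Any claim that something is new, unique, unknown or untested is made for them only; others in the source may bear on it.

In a functional assay on MCF-10A cells (Homo sapiens) for antiproliferative activity, with a stated time of 48 h (a lower number here means that less compound is needed, a higher number that more compound is needed for the effect), compound 1 `COc1ccc2nc(C)cc(NCc3ccccc3)c2c1` gives 25900 nM and compound 2 `COc1ccc2nc(C)cc(NCc3ccncc3)c2c1` gives 40900 nM while compound 3 `COc1ccc2nc(C)cc(NCc3cccnc3)c2c1` gives 44800 nM and so stands level with both within the scatter. Compound 4 `COc1ccc2nc(C)cc(NCc3ccc(C)cc3)c2c1` carries 4-methylphenyl in place of pyridin-3-yl on a saturated chain carbon bound to a nitrogen on an aromatic ring. The step of a 1.7-fold higher number from compound 1 to compound 3 (0.24 log units; within the scatter) exchanges phenyl for pyridin-3-yl and lies within the scatter, as do a 1.6-fold higher number from compound 1 to compound 2 (0.20 log units; within the scatter) and a 1.1-fold higher number from compound 2 to compound 3 (0.04 log units; within the scatter) among these groups. Going by the values given here, no measured compound carries 4-methylphenyl, so that group itself remains untested. No step beyond the scatter is therefore expected, and the estimated move is (a 1.7-fold lower number from compound 3 to compound 4 (0.22 log units; within the scatter)). Compound 4 is expected at 27000 nM with an estimated range from 13000 nM to 55000 nM in this assay overall.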

Compound 4, half-maximal effective concentration: 18800 nM
Estimate against measurement, compound 4: 1.4-fold (0.16 log units) above; measured number inside the range.
By their numbers in this assay, from the lowest: compounds 4, 1, 2 and 3 (each within the scatter of the next, the first and the last beyond it).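

In this assay, going by these compounds alone, 4-methylphenyl on a saturated chain carbon bound to a nitrogen on an aromatic ring gives the first steps at this position beyond the scatter, both modest: a 2.4-fold lower number from compound 3 to compound 4 (0.38 log units; beyond the scatter) and a 2.2-fold lower number from compound 2 to compound 4 (0.34 log units; beyond the scatter). Methyl in place of hydrogen on an aromatic carbon is by itself no separable change, a 1.4-fold lower number from compound 1 to compound 4 (0.14 log units; within the scatter), so phenyl stands level with 4-methylphenyl and with both pyridinyl groups. Nothing given here explains these steps. From the compounds shown here alone, whether chloro, methoxy or a carboxylic acid in place of that methyl would give a larger step stays open, as does the effect of a longer chain in place of the single chain carbon.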